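Phenoxy in Place of Phenyl on a Shared Core

The source may report more compounds than this note shows. Statements on the series, on what has been measured and on what is new or still open speak of the compounds shown alone.

Of the compounds shown here, three on one shared core have been measured in an assay on membranes from Jurkat cells for displacement of a labelled ligand from Sigma intracellular receptor 2 (Homo sapiens), read by scintillation counting, with a stated time of 1 h; a lower number here means a stronger inhibitor, a higher number a weaker inhibitor. Compound 1 `Cn1nc(CN2CCCC2)nc1-c1cccc(-c2ccccc2)c1` gives 1000 nM in this assay. Compound 3 `Cn1nc(CN2CCCC2)nc1-c1ccc2c(c1)CCC2` gives 1000 nM in this assay, level with compound 1 at the digits shown and within the usual scatter of it. Compound 2 `Cn1nc(CN2CCCC2)nc1-c1ccc(Cl)cc1` gives > 1000 nM in this assay, which is a limit of the assay and not a number; it sits at the limit of > 1000 nM in this assay, at which 1 of the 3 values shown sits. No pair among these three differs in a single place, so no measured step is available.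

Compound 4 `Cn1nc(CN2CCCC2)nc1-c1cccc(Oc2ccccc2)c1` is not yet measured. It differs from compound 1 by phenoxy in place of phenyl on an aromatic carbon, meta to a large group. Going by the values given here, with no measured step to guide the size, the step from compound 1 to compound 4 is expected to stay within the scatter, estimated as a 1.3-fold lower number from compound 1 to compound 4 (0.10 log units; within the scatter). Compound 4 is therefore expected to give about 800 nM in this assay, with a range from 300 nM to 3000 nM.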

Compound 4, inhibition constant: > 1000 nM
Compound 4: a limit, no number; the forecaster's own chance of this, stated with the estimate: 25%; at least 1.2-fold (0.09 log units) between middle value and limit.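

Going by these compounds alone, this gives the first measured step on the shared core, at the aromatic carbon meta to a large group: phenoxy in place of phenyl gives a number no lower from compound 1 to compound 4 (the limit leaves the size open). So the change brings no lower number in this assay, although how far the number rises, if it rises at all, cannot be read. Compound 4 stands at a limit of the assay and not at a number, and that limit now covers more of the set: the limit of > 1000 nM in this assay, at which 2 of the 4 values shown sit.

The compounds shown leave open whether an amine, a carboxylic acid or a longer chain carrying the phenyl ring at this position would give a lower number than compound 1 at 1000 nM. They also leave open where the true value of compound 4 lies.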